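A few compounds are considered here, and "the series" means these few. Any claim that something is new, unique, unknown or untested is made for them only; others in the source may bear on it.

For the measured compounds named here, compound 1 `Nc1nc(Cl)c2ncn(Cc3ccccc3CCl)c2n1` gives the higher of the two numbers measured so far: in a functional assay on Hs-578T cells (Homo sapiens) for cytotoxicity, read by sulforhodamine B assay, with a stated time of 48 h (on this read-out lower numbers stand for stronger inhibition of growth and higher numbers for weaker inhibition of growth), compound 1 gives 7760 nM. Compound 2 `ClCc1ccccc1Cn1cnc2ncnc(Cl)c21` sits lower; in this assay compound 2 gives 2290 nM, and that gap from compound 1 lies beyond the scatter. Compound 3 `ClCc1ccccc1Cn1cnc2c(Cl)nc(Cl)nc21` is not yet measured. It differs from compound 1 by chloro in place of amino on an aromatic carbon, the change sitting on an aromatic carbon between two ring nitrogen atoms, meta to a chloro group. Going by the values given here, no measured step of this kind exists, so the expected move in this assay is a modest shift toward a lower number, estimated as a 2.6-fold lower number from compound 1 to compound 3 (0.41 log units; beyond the scatter). For compound 3 in this assay the estimate is 3000 nM, with an expected range from 1200 nM to 8000 nM.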

Compound 3, concentration for 50% growth inhibition: 1170 nM
Beside the measured number, compound 3's estimate is 2.6-fold (0.41 log units) above it, and the stated range ends above it.
By their numbers in this assay, from the lowest: compounds 3 and 2 (each within the scatter of the next); then compound 1.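

At this aromatic carbon between two ring nitrogen atoms, the amino group carries a real penalty in this assay: chloro in place of amino gives a 6.6-fold lower number from compound 1 to compound 3 (0.82 log units; beyond the scatter) and this step lies beyond the scatter. Compound 3 and compound 2 lie within the scatter of each other, so only compound 1 stands apart among the three. No evidence on the origin of this step is available.
From the compounds shown here alone, whether methoxy, methyl or dimethylamino at this carbon would read like amino or like chloro remains open. Every compound shown also keeps the chloromethyl group, so its contribution cannot be read from them.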